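Working notes: methoxy for chloro on the shared core

This account rests on a few compounds, and the source may have more. Where it says the series, first, only, none or still open, it means among the compounds named here.

Measured so far in an assay on isolated protein for displacement of a labelled ligand from 5-hydroxytryptamine receptor 4 (Cavia porcellus); a higher number here means a weaker inhibitor, a lower number a stronger inhibitor:
compound 1, `CN1CCN(CCNC(=O)n2c(=O)[nH]c3ccccc32)CC1`: 1000 nM
compound 2, `CC(C)n1c(=O)n(C(=O)NCCN2CCN(C)CC2)c2cc(Cl)ccc21`: > 1000 nM

The value for compound 2 is a limit of the assay and not a number; this is the limit of > 1000 nM in this assay, at which 1 of the 2 values shown sits. Compound 1 gives a number, 1000 nM. Among the measured compounds shown here, no two measured compounds differ in one place, so the two values can only be set side by side as they stand: compound 1 has a number, compound 2 only a limit, and the two cores are not the same.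

Compound 3, `COc1ccc2c(c1)n(C(=O)NCCN1CCN(C)CC1)c(=O)n2C(C)C`, is not yet measured. Against compound 2 the change is methoxy in place of chloro on an aromatic carbon. For the measured compounds named here, no measured step bears on this change, and compound 2 itself gives only a limit, so there is no anchor for the size of the step. In this assay the step is expected to be small, with no direction beyond the scatter: a step that the limit leaves unreadable from compound 2 to compound 3. Compound 3 is expected to give about 1500 nM in this assay, between 300 nM and 8000 nM, with a fair chance that only a limit is reported again.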

Compound 3, half-maximal inhibitory concentration: > 1000 nM
Compound 3: no number, only a limit (the forecaster's own chance of this, stated with the estimate: 55%); the middle value does not contradict the limit.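

In this assay compound 3 gives > 1000 nM, a limit of the assay and not a number. Compound 2 also gives only a limit, so no step can be read between compound 2 and compound 3: the limit of > 1000 nM in this assay, at which 2 of the 3 values shown sit.

The compounds shown leave open whether methoxy in place of chloro on an aromatic carbon changes the value in this assay at all, and in which direction.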